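Swapping the Amide Aryl Group in a Weak Cell Growth Inhibitor

This account rests on a few compounds, and the source may have more. Where it says the series, first, only, none or still open, it means among the compounds named here.

Of the compounds shown here, two sharing one core have been tested in a functional assay on GTL 16 cells for antiproliferative activity against GTL 16 cell line (Homo sapiens), read by CCK-8 assay, with a stated time of 72 h; on this read-out higher numbers stand for weaker inhibition and lower numbers for stronger inhibition. Compound 1 `COc1ccc(C(=O)Nc2cccc(-c3oc4cc(-c5ccc(F)cc5)ccc4c(=O)c3O)c2)cc1` gives 21100 nM in this assay. Compound 2 `Cc1cc(C)cc(C(=O)Nc2cccc(-c3oc4cc(-c5ccc(F)cc5)ccc4c(=O)c3O)c2)c1` gives 13500 nM in this assay. The step between them, a 1.6-fold lower number from compound 1 to compound 2 (0.19 log units; within the scatter), is the only one measured, and it shows that exchanging the aryl group on the carbonyl carbon left the read-out essentially unchanged; compound 2 and compound 1 therefore sit within the scatter of each other, and neither can be called the more active.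

Compound 3 `O=C(Nc1cccc(-c2oc3cc(-c4ccc(F)cc4)ccc3c(=O)c2O)c1)c1ccc(Cl)nc1` has not yet been measured. It differs from compound 2 in one place: 6-chloropyridin-3-yl in place of 3,5-dimethylphenyl on a carbonyl carbon. For the measured compounds named here, this is again an exchange of the aryl group on the carbonyl carbon of the amide, the same kind of change as the one measured step, which was within the scatter. On that basis no step beyond the scatter is expected for compound 3 in this assay, and the estimated step of a 1.1-fold higher number from compound 2 to compound 3 (0.05 log units; within the scatter) is expected to stay within it. Compound 3 is thus estimated at 15000 nM, with a range from 5000 nM to 45000 nM.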

Compound 3, half-maximal inhibitory concentration: 7520 nM
Compound 3: middle estimate off by 2.0-fold (0.30 log units), on the high side; the range from low to high includes it.
By their numbers in this assay, from the lowest: compounds 3, 2 and 1 (each within the scatter of the next, the first and the last beyond it).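

For the compounds shown here, exchanging the aryl group on the carbonyl carbon gives a 2.8-fold lower number from compound 1 to compound 3 (0.45 log units; beyond the scatter) in this assay and this is the first modest step at this position to lie beyond the scatter. The other new step, a 1.8-fold lower number from compound 2 to compound 3 (0.25 log units; within the scatter) in this assay, stays within the scatter, so compound 3 cannot be ranked ahead of compound 2, and its separation holds against compound 1 alone. The entering 6-chloropyridin-3-yl group has one six-membered aromatic ring with 1 hetero atom and 1 hydrogen-bond acceptor, but no available evidence explains why it separates from the 4-methoxyphenyl group of compound 1.

The compounds shown carry only aromatic rings on this carbonyl carbon, so it remains open whether a piperidine ring or a short alkyl chain there would give a similar number. Going by these compounds, it also remains open whether the chlorine or the ring nitrogen of compound 3 accounts for its separation from compound 1, a question that a plain pyridin-3-yl group and a 4-chlorophenyl group could help to settle.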